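Hexyl to 2,2,2-trifluoroethyl: notes on compound 4

The compounds below may be only part of what the source reports. "The series", "measured", "known", "first", "only" and "open" are said of these compounds alone.

Values in a functional assay on SH-SY5Y cells (Homo sapiens) for antagonist activity, read by cAMP accumulation; a lower number here means a less potent compound, a higher number a more potent compound, by a factor of ten per unit of this negative logarithm:
- compound 1 `CCCOc1ccc(Cc2ccc(NC3=NCCN3)cc2)cc1`: 8.8
- compound 2 `CC(C)COc1ccc(Cc2ccc(NC3=NCCN3)cc2)cc1`: 8.8
- compound 3 `CCCCCCOc1ccc(Cc2ccc(NC3=NCCN3)cc2)cc1`: 8.2

Compound 3 stands lowest of the three, with a number 0.60 log units lower from compound 1 to compound 3 (beyond the scatter) and a number 0.60 log units lower from compound 2 to compound 3 (beyond the scatter). The branched chain made no difference, with no change at the digits printed from compound 1 to compound 2 (within the scatter).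

Compound 4 `FC(F)(F)COc1ccc(Cc2ccc(NC3=NCCN3)cc2)cc1` is the next case, and the change is trifluoromethyl in place of pentyl on a saturated chain carbon bound to an oxygen on an aromatic ring: trifluoromethyl in place of pentyl, on a saturated chain carbon bound to an oxygen on an aromatic ring. Among the compounds with values here, no measured compound carries trifluoromethyl. Within the data shown here, the only guide is the modest fall on reaching compound 3, a number 0.60 log units lower from compound 2 to compound 3 (beyond the scatter), and a partial reversal of it is expected. The expected step is a number 0.40 log units higher from compound 3 to compound 4 (beyond the scatter). For compound 4 the estimated value is 8.6, with an expected range of 8 to 9.1.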

Compound 4, negative logarithm of the antagonist equilibrium constant: 8.7
Compound 4: the middle estimate sits 0.10 log units below what was measured; the measured number falls inside the stated range.
By their numbers in this assay, from the lowest: compound 3; then compounds 4, 1 and 2 (each within the scatter of the next).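

At this position, a number 0.50 log units higher from compound 3 to compound 4 (beyond the scatter) in this assay, so the fall seen with hexyl does not extend to every replacement here. Fluorine is tolerated on this chain: a number 0.10 log units lower from compound 2 to compound 4 (within the scatter) and a number 0.10 log units lower from compound 1 to compound 4 (within the scatter), placing the three compounds level. Nothing measured here accounts for the recovery.

Compound 4 changes both chain length and fluorine content at once, and the two remain unseparated. An ethyl chain or a 2,2-difluoroethyl chain at this position would bear on that question.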